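The source may report more compounds than this note shows. Statements on the series, on what has been measured and on what is new or still open speak of the compounds shown alone.

Working notes on the series.

Compound 1 `CCOC(=O)C1=C(C)NC(=O)NC1c1cn(-c2ccccc2)nc1-c1ccc(Cl)cc1` carries an ethoxycarbonyl on the shared core. In a functional assay on MCF7 cells (Homo sapiens) for inhibition, read by sulforhodamine B assay, with a stated time of 24 h (on this read-out higher numbers stand for weaker inhibition of growth and lower numbers for stronger inhibition of growth), compound 1 gives 68800 nM. Compound 2 `CCOC(=O)C1=C(C)NC(=S)NC1c1cn(-c2ccccc2)nc1-c1ccc(Cl)cc1` differs from compound 1 in the core itself; the difference between the two cores is not broken down here. In this assay compound 2 gives 33200 nM, a lower number than that of compound 1, and the two values lie beyond the usual scatter of each other.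

Compound 3 `CC1=C(C(=O)Nc2ccccc2)C(c2cn(-c3ccccc3)nc2-c2ccc(Cl)cc2)NC(=O)N1` is compound 1 with anilino in place of ethoxy on a carbonyl carbon. In this assay compound 3 gives 65500 nM; the step of a 1.1-fold lower number from compound 1 to compound 3 (0.02 log units; within the scatter) is within the scatter, so on the core of compound 1 this exchange leaves the read-out essentially unchanged. The values of compound 2 and compound 3 lie within the scatter of each other, so no order between them is drawn.

Compound 4 `CC1=C(C(=O)Nc2ccccc2)C(c2cn(-c3ccccc3)nc2-c2ccc(Cl)cc2)NC(=S)N1` is not yet measured. It is compound 2 with anilino in place of ethoxy on a carbonyl carbon, and the place of the change reads the same word for word as in the step from compound 1 to compound 3, so this is the same change made on the other core. Among the measured compounds shown here, for compound 4 in this assay a step of about a 1.1-fold lower number from compound 2 to compound 4 (0.03 log units; within the scatter) is expected, resting on the single earlier example, in which the step of a 1.1-fold lower number from compound 1 to compound 3 (0.02 log units; within the scatter) stayed within the scatter. That step is applied to the starting point of compound 2, which gives 33200 nM. The estimate for compound 4 is accordingly 31000 nM, expected to fall between 14000 nM and 70000 nM.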

Compound 4, concentration for 50% growth inhibition: 61500 nM
Compound 4: the middle estimate sits 2.0-fold (0.30 log units) below what was measured, within the range that was stated.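

In this assay, anilino in place of ethoxy on a carbonyl carbon gives a 1.9-fold higher number from compound 2 to compound 4 (0.27 log units; within the scatter), so on the core of compound 2, as on the core of compound 1, this exchange stays inside the usual scatter. Set side by side, the two steps cannot be told apart: the same change on two cores in this assay, a 1.1-fold lower number (0.02 log units; within the scatter) from compound 1 to compound 3 and a 1.9-fold higher number (0.27 log units; within the scatter) from compound 2 to compound 4, 1.9-fold (0.29 log units) apart, within the scatter of two such steps

Within this pair of cores, the step therefore carries over as far as the data can show, with ethoxycarbonyl to phenylcarbamoyl leaving the read-out essentially unchanged on both; this does not show that the core has no influence on the exchange, since the two steps point in opposite directions by amounts that this read-out cannot resolve, and two examples on two cores support no general rule for the series.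

The compounds shown leave open whether other groups on the same carbonyl carbon, such as a longer alkoxy chain like butoxy, a saturated amine like morpholine, or a carboxylic acid, would also stay within the scatter on either core. They also leave open whether a substituted anilino, for example one carrying a methoxy group on its ring, would separate the two cores where the unsubstituted anilino does not.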